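The compounds below may be only part of what the source reports. "The series", "measured", "known", "first", "only" and "open" are said of these compounds alone.

Among the measured compounds shown here, in a physicochemical assay for solubility (a lower number here means a less soluble compound, a higher number a more soluble compound), compound 2 `CNC(=O)c1cccn(Cc2ccccc2)c1=O` gives 78 ug/mL, the only true number among the values so far. The step to compound 4 `CNC(=O)c1cc(C(=O)NCCO)cn(Cc2ccccc2)c1=O` is (2-hydroxyethyl)carbamoyl in place of hydrogen on an aromatic carbon. Compound 1 `CNC(=O)c1cc(C(=O)NC2CC2)cn([C@H](C)c2ccccc2)c1=O`, which also carries a carbamoyl group on that aromatic carbon, stands at >= 168 ug/mL, a limit of the assay. Compound 3 `CNC(=O)c1cc(C(=O)NC2CC2)cn(CC2CCCCC2)c1=O`, with a carbamoyl group in the same place, stands at >= 148 ug/mL, also a limit. For the measured compounds named here, the one measured step is a step that the two limits leave unreadable from compound 1 to compound 3, so it gives no size to carry over. Both limits lie higher than the number for compound 2, so a rise beyond the scatter is expected in this assay. The estimated change is a 1.9-fold higher number from compound 2 to compound 4 (0.28 log units; within the scatter). Compound 4 is expected at 150 ug/mL, within an estimated range of 85 ug/mL to 230 ug/mL.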

Compound 4, solubility: >= 140 ug/mL
Compound 4: only a limit was reported; the forecaster's own chance of this, stated with the estimate: 55%; the middle value is on the limit's open side.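

In this assay, putting (2-hydroxyethyl)carbamoyl in place of hydrogen on this aromatic carbon, two atoms from the ring nitrogen, gives an at least 1.7-fold higher number from compound 2 to compound 4 (0.25 log units; that floor lies within the scatter), the first step shown at this position. That floor does not establish a rise beyond the scatter, and the true size of the step stays unread. Compound 4 stands at >= 140 ug/mL, which is a limit of the assay and not a number: the limit of >= 140 ug/mL in this assay, at which 1 of the 4 values shown sits.

The step between compound 1 and compound 3 cannot be read. As far as these compounds go, it remains open whether a carboxylic acid or an amine on this aromatic carbon would give a true number.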